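Methoxy to dimethylamino on the shared core

This account rests on a few compounds, and the source may have more. Where it says the series, first, only, none or still open, it means among the compounds named here.

Compound 1 `COc1cc(Oc2ccc(NC(=O)Nc3cccc(C(F)(F)F)c3)cc2)ncn1` stands at the top of the two numbers in an assay on isolated protein for inhibition of serine/threonine-protein kinase TNNI3K (Homo sapiens); a lower number here means a stronger inhibitor, a higher number a weaker inhibitor: compound 1 gives 4000 nM. Compound 2 `CNc1cc(Oc2ccc(NC(=O)Nc3cccc(C(F)(F)F)c3)c(F)c2)ncn1` gives 63 nM in this assay; compound 2 differs from compound 1 in two places at once, so its gap to compound 1 is not resolved into single steps and only the two values themselves can be compared. Compound 3 `CN(C)c1cc(Oc2ccc(NC(=O)Nc3cccc(C(F)(F)F)c3)cc2)ncn1` is not yet measured. It differs from compound 1 in one place: dimethylamino in place of methoxy on an aromatic carbon. Within the data shown here, no measured pair isolates this exchange. Compound 2 reads 63 nM with an amine at the same place, which supports a lower number for compound 3, though the second change in compound 2 leaves part of that gap unassigned. A moderate step toward a lower number is expected, a 6.7-fold lower number from compound 1 to compound 3 (0.82 log units; beyond the scatter). For compound 3 in this assay the estimate is 600 nM, with a range from 150 nM to 2500 nM.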

Compound 3, half-maximal inhibitory concentration: 2500 nM
The estimate for compound 3 lay 4.2-fold (0.62 log units) below the measured number; low and high end bracket the measured number.
By their numbers in this assay, from the lowest: compound 2; then compounds 3 and 1 (each within the scatter of the next).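

Among these compounds, this is the first pair that isolates a single exchange at this place on the shared core: dimethylamino in place of methoxy on an aromatic carbon gives a 1.6-fold lower number from compound 1 to compound 3 (0.20 log units; within the scatter) in this assay, so the two groups cannot be told apart here. The extra heavy atom and the swap of oxygen for nitrogen therefore leave the number of compound 3 level with that of compound 1 in this assay. Nothing at hand bears on why these two groups read alike.

On these data alone, how the value of compound 2, 63 nM, divides between its two changes remains open. Also open, as far as these compounds go, is whether an unsubstituted amine, methylamino on the core of compound 1, or a longer chain such as ethoxy at this place would depart from compound 1.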